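Series notes: three measured compounds and one estimate

A few compounds are considered here, and "the series" means these few. Any claim that something is new, unique, unknown or untested is made for them only; others in the source may bear on it.

Measured values in a functional assay on A549 cells (Homo sapiens) for inhibition, read by MTT assay and WST assay, with a stated time of 72 h, tested at 10 uM; on this read-out higher numbers stand for more inhibition of growth at the one concentration tested and lower numbers for less inhibition of growth:
compound 1, `O=C(Nc1ccc(Oc2ccc(-c3nccs3)cc2)cc1)Nc1ccc(F)c(Cl)c1`: 37.3%
compound 2, `CC(=O)Oc1sccc1NC(=O)Nc1ccc(Oc2ccc(-c3nccs3)cc2)cc1`: 6.78%
compound 3, `O=C(Nc1ccc(Oc2ccc(-c3ncc[nH]3)cc2)cc1)Nc1ccc(F)c(Cl)c1`: 14.6%

Compound 2 differs from compound 1 by 2-acetoxythiophen-3-yl in place of 3-chloro-4-fluorophenyl on an amide-type nitrogen. In this assay this gave a number 30.5 percentage points lower from compound 1 to compound 2 (beyond the scatter). Compound 3 differs from compound 1 in the core, by 1H-imidazol-2-yl in place of 1,3-thiazol-2-yl on an aromatic carbon, and that gave a number 22.7 percentage points lower from compound 1 to compound 3 (beyond the scatter). The values of compound 2 and compound 3 lie within the usual scatter of each other, so no order between those two is claimed. Compound 1 stands beyond the scatter above both.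

Compound 4, `CC(=O)Oc1sccc1NC(=O)Nc1ccc(Oc2ccc(-c3ncc[nH]3)cc2)cc1`, has not yet been measured. It differs from compound 3 by 2-acetoxythiophen-3-yl in place of 3-chloro-4-fluorophenyl on an amide-type nitrogen. The place is described in the same words as for the change from compound 1 to compound 2, so this is the same change, applied here on the core of compound 3 rather than on the core of compound 1. The change has been measured once only.

The expected step is a number 10.6 percentage points lower from compound 3 to compound 4 (beyond the scatter), because the same change gave a number 30.5 percentage points lower from compound 1 to compound 2 (beyond the scatter), while compound 3 starts from 14.6% and has much less room to fall before the read-out reaches no growth inhibition at all. Compound 4 is therefore expected near 4% in this assay. The likely range for compound 4 runs from -10% to 18%. With a single prior instance of the change, this estimate rests on a thin base.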

Compound 4, percent growth inhibition at one concentration: 2.34%
Compound 4: middle estimate off by 1.7 percentage points, on the high side; low and high end bracket the measured number.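

The change to 2-acetoxythiophen-3-yl in place of 3-chloro-4-fluorophenyl on an amide-type nitrogen keeps its direction on the core of compound 3 in this assay, with a number 12.3 percentage points lower from compound 3 to compound 4 (beyond the scatter), but its size does not carry over from the core of compound 1: the same change on two cores in this assay, a number 30.5 percentage points lower (beyond the scatter) from compound 1 to compound 2 and a number 12.3 percentage points lower (beyond the scatter) from compound 3 to compound 4, 18.3 percentage points apart, beyond the scatter of two such steps

Read on the compounds bearing 2-acetoxythiophen-3-yl, the change to 1H-imidazol-2-yl in place of 1,3-thiazol-2-yl gives a number 4.4 percentage points lower from compound 2 to compound 4 (within the scatter), so in this assay the size of this change does not carry over either: the same change on two cores in this assay, a number 22.7 percentage points lower (beyond the scatter) from compound 1 to compound 3 and a number 4.4 percentage points lower (within the scatter) from compound 2 to compound 4, 18.3 percentage points apart, beyond the scatter of two such steps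

These two comparisons come from the same four compounds and amount to one observation of two changes that do not add up, and a single tested concentration, with compound 4 at 2.34%, cannot separate a true dependence on the core from a read-out lying close to no growth inhibition.

On these data alone, it remains open whether the loss in this assay belongs to the thiophene ring or to the acetoxy group, which a thiophen-3-yl without the acetoxy group or a plain phenyl on the amide-type nitrogen would address. Also open, as far as these compounds go, is how an amine or a carboxylic acid on the aromatic carbon now carrying 1,3-thiazol-2-yl or 1H-imidazol-2-yl would behave, and whether full concentration-response curves would show the same differences.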